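Pyrazolyl in place of phenyl: notes toward compound 3

The source may report more compounds than this note shows. Statements on the series, on what has been measured and on what is new or still open speak of the compounds shown alone.

Within the data shown here, compound 1 `O=C(O)Cc1sc(C(c2ccc(F)cc2)c2ccc(F)cc2)nc1-c1ccccc1` holds the only number so far in an in vitro functional assay on HEK285-7 cells for antagonist activity at prostaglandin D2 receptor 2 (Homo sapiens), read by BRET and beta-arrestin recruitment; on this read-out lower numbers stand for stronger inhibition and higher numbers for weaker inhibition; in this assay compound 1 gives 240 nM. Compound 2 `O=C(O)Cc1sc(C(c2ccccc2)c2ccccc2)nc1-c1ccc(C(F)(F)F)cc1` reaches only a limit of the assay, giving > 100000 nM, which is the limit of > 100000 nM in this assay, at which 1 of the 2 values shown sits. Among the measured compounds shown here, compound 2 differs from compound 1 in two places, so the pair sets no single step. Compound 3 `O=C(O)Cc1sc(C(c2ccc(F)cc2)c2ccc(F)cc2)nc1-c1cn[nH]c1` carries 1H-pyrazol-4-yl in place of phenyl on an aromatic carbon. For the measured compounds named here, no measured step fixes the size of this change; a loss somewhat beyond the scatter is expected, a 3.8-fold higher number from compound 1 to compound 3 (0.57 log units; beyond the scatter). Compound 3 is estimated at 900 nM, within 150 nM to 6000 nM.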

Compound 3, half-maximal inhibitory concentration: 220 nM
Beside the measured number, compound 3's estimate is 4.1-fold (0.61 log units) above it; low and high end bracket the measured number.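

In this assay, among these compounds, the first single-place step is a 1.1-fold lower number from compound 1 to compound 3 (0.04 log units; within the scatter), where phenyl gives way to 1H-pyrazol-4-yl. This aromatic carbon, next to the ring nitrogen, therefore accepts a five-membered aromatic ring with 2 hetero atoms, 1 hydrogen-bond donor and 1 hydrogen-bond acceptor, with the number staying within the scatter. Nothing available accounts for this result.

From the compounds shown here alone, whether the donor hydrogen of the pyrazole contributes remains open, and 1-methyl-1H-pyrazol-4-yl would address that. Going by these compounds, it also remains open whether a pyridin-3-yl ring fits this position equally well.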